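The compounds below may be only part of what the source reports. "The series", "measured", "known", "first", "only" and "open" are said of these compounds alone.

In a functional assay on MDA-MB-231 cells (Homo sapiens) for cytotoxicity, read by MTT assay (on this read-out lower numbers stand for stronger inhibition and higher numbers for weaker inhibition), compound 3 `Cc1nnc(-c2c[nH]c3ccccc23)o1` gives > 1000000 nM, which is a limit of the assay rather than a measured number. Compound 1 `c1ccc(Cc2nnc(-c3c[nH]c4ccccc34)o2)cc1` gives > 1000000 nM, again a limit. Compound 2 `c1cncc(-c2nnc(-c3c[nH]c4ccccc34)o2)c1` gives > 1000000 nM, also a limit. All three values therefore sit at the limit of > 1000000 nM in this assay, at which 3 of the 3 values shown sit, and for that reason the steps a step that the two limits leave unreadable from compound 1 to compound 2, a step that the two limits leave unreadable from compound 1 to compound 3 and a step that the two limits leave unreadable from compound 2 to compound 3 cannot be read in size or in direction. Compound 4 `FC(F)(F)c1nnc(-c2c[nH]c3ccccc23)o1` differs from compound 3 by trifluoromethyl in place of methyl on an aromatic carbon. Going by the values given here, none of the measured steps gives a readable size that bears on this exchange; every change tried so far on the shared core, from benzyl to pyridin-3-yl to methyl, left the result at the limit. The expectation for compound 4 is therefore that the step of a number no higher from compound 3 to compound 4 (the limit leaves the size open) stays within the scatter, and that the assay again reports only a limit. The estimate for compound 4 in this assay is 1000000 nM, with a range from 300000 nM to 3000000 nM.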

Compound 4, half-maximal inhibitory concentration: > 1000000 nM
Compound 4: no number, only a limit; the forecaster's own chance of this, stated with the estimate: 85%; the middle value lies on the limit itself.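

Compound 4 also gives only a limit, so its steps from compound 1, compound 2 and compound 3 cannot be read in size or direction: the limit of > 1000000 nM in this assay, at which 4 of the 4 values shown sit. The compounds shown leave open whether any change gives a readable value in this assay on the shared core.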